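From Tert-Butyl to Chloro: What Compound 4 Should Show

A few compounds are considered here, and "the series" means these few. Any claim that something is new, unique, unknown or untested is made for them only; others in the source may bear on it.

Three measured compounds share one core and differ only in the group on the outer aromatic ring. Compound 1 `Nc1ccccc1NC(=O)c1ccc(CSc2ccc(Br)cc2)cc1` carries a bromo group, and in a functional assay on HCT-116 cells (Homo sapiens) for inhibition, read by CCK-8 assay, with a stated time of 72 h, tested at 2 uM (a lower number here means less inhibition of growth, a higher number more inhibition of growth at the concentration tested), compound 1 gives 9.96%. Compound 2 `Cc1ccc(SCc2ccc(C(=O)Nc3ccccc3N)cc2)cc1` carries a methyl group, and in this assay compound 2 gives 74.8%. Compound 3 `CC(C)(C)c1ccc(SCc2ccc(C(=O)Nc3ccccc3N)cc2)cc1` carries a tert-butyl group, and in this assay compound 3 gives 4.81%, the lowest of the three numbers; it sits within the scatter of compound 1 but far from compound 2, as the steps of a number 5.2 percentage points lower from compound 1 to compound 3 (within the scatter) and a number 70 percentage points lower from compound 2 to compound 3 (beyond the scatter) show.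

Compound 4 `Nc1ccccc1NC(=O)c1ccc(CSc2ccc(Cl)cc2)cc1` is the chloro analogue; the change from compound 3 is chloro in place of tert-butyl on an aromatic carbon. Of the measured steps, the exchange of bromo for tert-butyl, a number 5.2 percentage points lower from compound 1 to compound 3 (within the scatter), bears most closely on this change: chloro and bromo are both halogens, and that step lay within the scatter. The large step of a number 64.8 percentage points higher from compound 1 to compound 2 (beyond the scatter) shows that a methyl group moves the number far, but no methyl is involved here. Compound 4 is therefore expected to show a step of a number 7.2 percentage points higher from compound 3 to compound 4 (within the scatter), not beyond the scatter. The estimate for compound 4 in this assay is 12%, with a range from 0% to 40%.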

Compound 4, percent growth inhibition at one concentration: 17.5%
For compound 4 the middle estimate is 5.5 percentage points below the measured one, and the stated range covers the measured number.
By their numbers in this assay, from the lowest: compounds 3, 1 and 4 (each within the scatter of the next, the first and the last beyond it); then compound 2.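

In this assay, putting chloro in place of tert-butyl at this place, para to a large group, gives a number 12.7 percentage points higher from compound 3 to compound 4 (beyond the scatter) and so shows that this exchange can move the number modestly, whereas the change between the two halogens gives a number 7.5 percentage points higher from compound 1 to compound 4 (within the scatter) and leaves chloro and bromo indistinguishable here. The step of a number 57.3 percentage points lower from compound 2 to compound 4 (beyond the scatter) adds a second halogen to the comparison with methyl and shows that the high number of compound 2 is not matched by chloro, just as it was not matched by bromo or tert-butyl. No evidence is available that explains why methyl stands so far from the other three groups at this position.

The compounds shown leave open whether the high number is confined to methyl or also appears with other groups at this place, such as an ethyl group, a methoxy group, an amine or a carboxylic acid. They also leave open whether the same order among these four compounds would hold at other concentrations, since each number here comes from a single tested concentration.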